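Swapping the thienyl for a methylphenyl in compound 2

The source may hold more compounds than are shown below. What is called first, only, known or untested is meant among the compounds shown, and "the series" means these compounds.

Among the measured compounds shown here, compound 2 `CC(C)C[C@H](N)CN(C(=O)[C@@H]1C[C@H]1c1ccccc1)c1ccc(-c2cccs2)cc1` is tested in a functional assay for agonist activity at G protein-coupled receptor 88 (Homo sapiens), read by HTRF and cAMP accumulation (a lower number here means that less compound is needed, a higher number that more compound is needed for the effect), and gives 1500 nM, the higher of the two numbers known so far. Compound 1 `CC[C@H](C)[C@H](N)CN(C(=O)[C@@H]1C[C@H]1c1cccc(C)c1)c1ccc(-c2ccccc2)cc1` gives 1200 nM in this assay, and the two values lie within the scatter of each other. Compound 3 `Cc1ccccc1-c1ccc(N(C[C@@H](N)CC(C)C)C(=O)[C@@H]2C[C@H]2c2ccccc2)cc1` differs from compound 2 by one change: 2-methylphenyl in place of thiophen-2-yl on an aromatic carbon. For the measured compounds named here, no measured pair isolates this change, so no step beyond the scatter is expected in either direction. The estimated step of a 1.3-fold lower number from compound 2 to compound 3 (0.10 log units; within the scatter) is small. Compound 3 is expected to give about 1200 nM, within 400 nM to 3600 nM.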

Compound 3, half-maximal effective concentration: 3400 nM
The estimate for compound 3 lay 2.8-fold (0.45 log units) below the measured number; low and high end bracket the measured number.
By their numbers in this assay, from the lowest: compounds 1 and 2 (each within the scatter of the next); then compound 3.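

In this assay, 2-methylphenyl in place of thiophen-2-yl gives a 2.3-fold higher number from compound 2 to compound 3 (0.36 log units; beyond the scatter), meaning more compound is needed for the effect. Among the compounds shown here, this is the first step beyond the scatter, and it shows that the group on this aromatic carbon, para to a large group, can change the number. No available measurement explains the change.

The compounds shown leave open whether the difference follows the methyl or the six-membered ring. Phenyl or pyridine rings on the core of compound 2 would help separate those two possibilities.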